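Nitro for fluoro on the aryl ring of a β-lactam

The compounds below may be only part of what the source reports. "The series", "measured", "known", "first", "only" and "open" are said of these compounds alone.

Measured so far:
Compound 1 `CCOC(=O)/C(=C/c1ccccc1)CN1C(=O)[C@@H](OC)[C@H]1c1cccc([N+](=O)[O-])c1`: 19900 nM
Compound 3 `COC(=O)/C(=C/c1ccccc1)CN1C(=O)[C@@H](OC)[C@H]1c1cccc(F)c1`: 13700 nM
Compound 2 `COC(=O)/C(=C/c1ccccc1)CN1C(=O)[C@@H](OC)[C@H]1c1cccc(C(F)(F)F)c1`: no result reported

In a functional assay on MCF7 cells (Homo sapiens) for antiproliferative activity, read by MTT assay, with a stated time of 48 h (a higher number here means a weaker inhibitor, a lower number a stronger inhibitor), compound 3 gives 13700 nM. Compound 1, which carries an ethyl rather than a methyl ester and a nitro group, gives 19900 nM in this assay; the gap between these two numbers lies within the scatter, so neither can be called the stronger inhibitor. Compound 4 `COC(=O)/C(=C/c1ccccc1)CN1C(=O)[C@@H](OC)[C@H]1c1cccc([N+](=O)[O-])c1` differs from compound 3 by nitro in place of fluoro on an aromatic carbon. Among the measured compounds shown here, no step of this kind has been measured between two compounds here. Compound 1, the other nitro-bearing compound, gives 19900 nM, so for compound 4 a step no larger than the scatter is expected. Compound 4 is estimated at 18000 nM in this assay, within 9000 nM to 40000 nM, corresponding to an expected 1.3-fold higher number from compound 3 to compound 4 (0.12 log units; within the scatter).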

Compound 4, half-maximal inhibitory concentration: 15000 nM
Compound 4: the middle estimate sits 1.2-fold (0.08 log units) above what was measured, within the range that was stated.
By their numbers in this assay, from the lowest: compounds 3, 4 and 1 (each within the scatter of the next).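

With the methyl ester held, nitro in place of fluoro on this aromatic carbon gives a 1.1-fold higher number from compound 3 to compound 4 (0.04 log units; within the scatter) in this assay, so the two groups cannot be told apart here. With the nitro group held, going from the ethyl ester to the methyl ester gives a 1.3-fold lower number from compound 1 to compound 4 (0.12 log units; within the scatter), so neither change separates these compounds. Nothing shown gives a cause for either result. Going by these compounds, whether an amine or a carboxylic acid on this aromatic carbon, or a longer chain on the ester, would give a step beyond the scatter stays open.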